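The compounds below may be only part of what the source reports. "The series", "measured", "known", "first", "only" and "open" are said of these compounds alone.

Three compounds on the shared core have numbers in a physicochemical assay for lipophilicity, measured as octanol-water partition; on this read-out lower numbers stand for lower lipophilicity and higher numbers for higher lipophilicity: compound 1 `O=C(NNc1ccnc2cc(Cl)ccc12)c1ccccc1/N=C/c1cccc(Cl)c1Cl` gives 6.1, compound 2 `COc1ccc(/C=N/c2ccccc2C(=O)NNc2ccnc3cc(Cl)ccc23)cc1` gives 5, and compound 3 `O=C(NNc1ccnc2cc(Cl)ccc12)c1ccccc1/N=C/c1ccc(O)cc1` gives 4.65. Compound 3 is therefore the lowest of the three, with compound 2 nearest and compound 1 furthest. Compound 4 `CN(C)c1ccc(/C=N/c2ccccc2C(=O)NNc2ccnc3cc(Cl)ccc23)cc1` has no number yet. It carries dimethylamino in place of hydroxy on an aromatic carbon, para to a large group (dimethylamino in place of hydroxy on an aromatic carbon).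

The most relevant measured step is the modest a number 0.35 log units lower from compound 2 to compound 3 (beyond the scatter), where hydrogen replaces methyl on an oxygen on an aromatic ring. Read in reverse, this step shows the number rising when the hydroxy of compound 3 is replaced, and compound 4 also lacks that hydroxy. The large steps of a number 1.10 log units lower from compound 1 to compound 2 (beyond the scatter) and a number 1.45 log units lower from compound 1 to compound 3 (beyond the scatter) bear on the question only loosely, since both start from compound 1, whose group at this position is absent from compound 4. They do show that this position can move this assay well beyond the scatter. A rise is therefore expected, similar to or somewhat larger than the step seen with compound 2. The expected step is a number 0.55 log units higher from compound 3 to compound 4 (beyond the scatter), which would be modest to moderate in size. For compound 4 the estimated value is 5.2, with an expected range of 4.8 to 5.6.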

Compound 4, partition coefficient: 5.03
For compound 4 the middle estimate is 0.17 log units above the measured one; low and high end bracket the measured number.
By their numbers in this assay, from the lowest: compound 3; then compounds 2 and 4 (each within the scatter of the next); then compound 1.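

In this assay, a number 0.38 log units higher from compound 3 to compound 4 (beyond the scatter), while the comparison with methoxy on the same aromatic carbon reads a number 0.03 log units higher from compound 2 to compound 4 (within the scatter), so the two groups cannot be told apart here and compound 3, with its hydroxy, remains alone at the low end. The series thus gains a second group that leaves the number level with compound 2, which makes the earlier gap between methoxy and hydroxy look less like a feature of methoxy alone, although two such groups are a narrow basis. The step of a number 1.07 log units lower from compound 1 to compound 4 (beyond the scatter) is of the same large class as a number 1.10 log units lower from compound 1 to compound 2 (beyond the scatter), so 2,3-dichlorophenyl stays well apart from both 4-(dimethylamino)phenyl and 4-methoxyphenyl, and no measurement shown accounts for any of these differences.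

On these data alone, what a primary amine or a carboxylic acid on this aromatic carbon would give in this assay stays open, as does the reading for a longer chain on the oxygen of compound 2. Also open is how much of the reading for compound 1 belongs to either chlorine alone, since a single chloro group on the phenyl ring does not appear among these compounds.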